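This account rests on a few compounds, and the source may have more. Where it says the series, first, only, none or still open, it means among the compounds named here.

Measured so far in an ADME assay on microsomes from liver (Rattus norvegicus) for metabolic stability, read by LC-MS, using NADPH, at 37 degrees C; a lower number here means that the compound disappears faster, a higher number that the compound lasts longer:
- compound 1 `Cc1cc(C)c(-c2nc(CN3CCC(C(=O)NCCCN4C[C@H](C)C[C@H](C)C4)CC3)c(C)o2)c(C)c1`: > 0.5 h (a limit of the assay, not a number)
- compound 2 `CC[C@@H]1C[C@H](CC)CN(CCCNC(=O)C2CCN(Cc3nc(-c4ccccc4C)oc3C)CC2)C1`: 0.0917 h
- compound 3 `Cc1oc(-c2ccccc2Cl)nc1CN1CCC(C(=O)NCCCN2C[C@H](C)C[C@H](C)C2)CC1`: 0.25 h

Compound 2, at 0.0917 h, sits lowest of the compounds shown, and compound 3, at 0.25 h, lies beyond the usual scatter from it. Compound 4 `Cc1ccccc1-c1nc(CN2CCC(C(=O)NCCCN3CCC(C(C)C)CC3)CC2)c(C)o1` has not been measured yet. It differs from compound 2 in one place: 4-isopropylpiperidin-1-yl in place of 3,5-diethylpiperidin-1-yl on a saturated chain carbon, three bonds along the chain from an amide-type nitrogen. Put simply, 4-isopropylpiperidin-1-yl stands in place of 3,5-diethylpiperidin-1-yl on a saturated chain carbon, three bonds along the chain from an amide-type nitrogen.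

Among the compounds with values here, only one measured step changes a single place, an at least 2.0-fold lower number from compound 1 to compound 3 (0.30 log units; that floor lies within the scatter). That step puts 2-chlorophenyl in place of 2,4,6-trimethylphenyl on an aromatic carbon, which is not the place that changes here, so it gives no direct guide to size or direction. Within the data shown here, no measured pair changes the group on the chain alone. The expectation therefore starts from compound 2 at 0.0917 h, and no change beyond the scatter is expected.

The estimated step is a 1.3-fold higher number from compound 2 to compound 4 (0.12 log units; within the scatter).

For compound 4 the expected half-life is 0.12 h, with an estimated range from 0.05 h to 0.3 h.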

Compound 4, half-life: 0.147 h
Estimate against measurement, compound 4: 1.2-fold (0.09 log units) below; the range from low to high includes it.
By their numbers in this assay, from the lowest: compounds 2, 4 and 3 (each within the scatter of the next, the first and the last beyond it). At a limit, above all of these: compound 1.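

Within the data shown here, compound 2 and compound 4 differ only in the group on the saturated chain carbon, three bonds along the chain from an amide-type nitrogen, so this is the first direct reading of a change at that place. In this assay, replacing 3,5-diethylpiperidin-1-yl with 4-isopropylpiperidin-1-yl gives a 1.6-fold higher number from compound 2 to compound 4 (0.20 log units; within the scatter). The swap removes one heavy atom and both defined stereocentres and rearranges the alkyl groups on the ring, yet the two half-lives cannot be told apart, and nothing shown offers a reason for this result.

From the compounds shown here alone, both groups are alkyl-substituted piperidines, so it remains open whether a piperidine with no alkyl group, a morpholine or a piperazine at this place would give a half-life beyond the scatter of these two values, and the same question applies to a longer chain leading to the ring. Going by these compounds, it is also open whether this swap would read the same in a compound carrying 2-chlorophenyl or 2,4,6-trimethylphenyl on its aromatic carbon, since each of those groups appears here only with a different piperidine.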